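Carboxyphenoxy for carboxyphenylamino in compound 3

The source may hold more compounds than are shown below. What is called first, only, known or untested is meant among the compounds shown, and "the series" means these compounds.

Measured compounds in a functional assay on HEK293 cells for agonist activity at Bile acid receptor (Homo sapiens), read by a luciferase reporter; on this read-out higher numbers stand for larger maximal responses and lower numbers for smaller maximal responses:
compound 1 `CC(C)c1onc(-c2c(Cl)cccc2Cl)c1COc1ccc(N(C)C(=O)c2ccc(C(=O)O)cc2)c(C(F)(F)F)n1` gives 63%
compound 2 `CC(C)c1onc(-c2c(Cl)cccc2Cl)c1COc1ccc(N(C)Cc2ccc(OCCO)cc2)c(C(F)(F)F)n1` gives 59%
compound 3 `CC(Nc1ccc(C(=O)O)cc1)c1ccc(OCc2c(-c3c(Cl)cccc3Cl)noc2C2CC2)nc1C(F)(F)F` gives 49%

The number for compound 3 is the lowest of the three in this assay. Its gap to compound 2 lies within the scatter, so the two cannot be ordered; its gap to compound 1 lies beyond the scatter. For the measured compounds named here, the only single-site step among the measured compounds is a number 4 percentage points lower from compound 1 to compound 2 (within the scatter), which concerns the substituent on the ring nitrogen of the core of compound 1 and says nothing about the arm that is varied here.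

Compound 4 `CC(Oc1ccc(C(=O)O)cc1)c1ccc(OCc2c(-c3c(Cl)cccc3Cl)noc2C2CC2)nc1C(F)(F)F` is the unmeasured compound. It differs from compound 3 in one place: 4-carboxyphenoxy in place of (4-carboxyphenyl)amino on a saturated chain carbon bound to an aromatic carbon and a saturated chain carbon. Going by the values given here, no measured pair shows this exchange or anything close to it, so there is no step to lean on. With one hydrogen-bond donor fewer and no other counted difference, the working expectation is that this assay gives no step beyond the scatter, in either direction.

Expected step: a number 2 percentage points lower from compound 3 to compound 4 (within the scatter), that is, no change beyond the scatter is expected. For compound 4 the estimated value in this assay is 47%, with a range from 28% to 66%.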

Compound 4, largest response reached (reported as efficacy), in percent of the reference or control that the assay uses: 33%
Compound 4: the middle estimate sits 14 percentage points above what was measured, within the range that was stated.
By their numbers in this assay, from the lowest: compound 4; then compounds 3, 2 and 1 (each within the scatter of the next, the first and the last beyond it).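

In this assay, the arm on the saturated chain carbon bound to an aromatic carbon and a saturated chain carbon responds to the atom that links it: 4-carboxyphenoxy in place of (4-carboxyphenyl)amino gives a number 16 percentage points lower from compound 3 to compound 4 (beyond the scatter). For the compounds shown here, this is the first single-site step that lies beyond the scatter, and it falls on this arm, whereas the earlier step concerned only the substituent on the ring nitrogen of the core of compound 1. Within the exchange, the carboxyphenyl ring and the heavy-atom count stay the same, and the counted differences are an oxygen for the nitrogen and a lower hydrogen-bond donor count, but no measurement here accounts for the step.

The compounds shown leave open whether a methylene link, a thioether sulfur or an N-methylamino link on the same arm would read closer to compound 3 or to compound 4. Also open, on these data alone, is whether the same exchange gives a step of similar size when the cyclopropyl group on the shared core is replaced by isopropyl.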